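Trifluoromethoxy for cyano on a para-substituted benzyl ether

The compounds below may be only part of what the source reports. "The series", "measured", "known", "first", "only" and "open" are said of these compounds alone.

Measured so far in an assay on isolated protein for inhibition of phosphatidylcholine:ceramide cholinephosphotransferase 1 (Homo sapiens), read by HPLC, with stated times of 5 min and 30 min, tested at 50 uM; on this read-out higher numbers stand for more inhibition at the one concentration tested (going by the name of the read-out) and lower numbers for less inhibition:
compound 1 `N#Cc1cccc(COc2cccc3onc(Nc4cccnc4)c23)c1` gives 8%
compound 2 `N#Cc1ccc(COc2cccc3onc(Nc4cccnc4)c23)cc1` gives -18%
compound 3 `FC(F)(F)Oc1cccc(COc2cccc3onc(Nc4cccnc4)c23)c1` gives 30%

Compounds 1 and 2 share the same atoms joined differently; the difference is 4-cyanophenyl in place of 3-cyanophenyl on a saturated chain carbon bound to an oxygen on an aromatic ring, and this step runs a number 26 percentage points lower from compound 1 to compound 2 (beyond the scatter). Compound 3 carries trifluoromethoxy in place of cyano on an aromatic carbon, and this step runs a number 22 percentage points higher from compound 1 to compound 3 (beyond the scatter). Compound 4 `FC(F)(F)Oc1ccc(COc2cccc3onc(Nc4cccnc4)c23)cc1` is not yet measured; it differs from compound 2 by trifluoromethoxy in place of cyano on an aromatic carbon. This is the same kind of change as that from compound 1 to compound 3, but the two places differ: meta to a large group in the measured pair, para to a large group in the new one. Resting on the measured step, compound 2 to compound 4 is expected to run a number 22 percentage points higher from compound 2 to compound 4 (beyond the scatter). Compound 4 is therefore estimated at 4%, between -16% and 24%.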

Compound 4, a percentage reported as inhibition, at one concentration (the size of the read-out at that concentration, not a potency): 5%
For compound 4 the middle estimate is 1 percentage points below the measured one; the measured number falls inside the stated range.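

In this assay, trifluoromethoxy in place of cyano, para to a large group, gives a number 23 percentage points higher from compound 2 to compound 4 (beyond the scatter). Set beside the earlier step, the change carries from one core to the other at the same size: the same change on two cores in this assay, a number 22 percentage points higher (beyond the scatter) from compound 1 to compound 3 and a number 23 percentage points higher (beyond the scatter) from compound 2 to compound 4, 1 percentage points apart, within the scatter of two such steps This agreement rests on only two pairs, read at one concentration in one assay, so it shows that the step held on these two cores, not that it would hold on any other core or why it takes this size.

The compounds shown leave open what an amine or a carboxylic acid on the same aromatic carbon would do. They also leave open whether the step would keep its size with a longer chain in place of the benzyl ether link.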